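The source may report more compounds than this note shows. Statements on the series, on what has been measured and on what is new or still open speak of the compounds shown alone.

Measured compounds:
compound 1 `CCCCCCCCCCCCCCC[C@H](O)[C@H](COP(=O)(O)O)N=[N+]=[N-]` gives 21800 nM
compound 2 `CCCCCCCCCCCCC/C=C/[C@@H](O)[C@@H](COP(=O)(O)O)N=[N+]=[N-]` gives 22900 nM

Both values come from an assay on isolated protein for inhibition of sphingosine-1-phosphate lyase 1 (Homo sapiens), read by fluorescence, with a stated time of 1 h (a higher number here means a weaker inhibitor, a lower number a stronger inhibitor), and compound 1 has the lower of the two numbers, with compound 2 only a little higher, a gap that lies within the scatter of repeated measurements, so the two cannot be told apart.

The next compound is compound 3, `CCCCCCCCCCCCCCC[C@@H](O)[C@@H](COP(=O)(O)O)N=[N+]=[N-]`. It differs from compound 1 in this way: the two compounds have the same atoms and bonds; at least one stereo element is drawn with a configuration in one of them and without one in the other: 2 of 3 stereo elements differ; a stereocentre at a saturated chain carbon is drawn S in compound 1 and R in compound 3; a stereocentre at a saturated chain carbon is drawn S in compound 1 and R in compound 3. The two are mirror images of each other: the same atoms and bonds, but both stereocentres reversed. Among the compounds with values here, no pair among the measured compounds shows what such a reversal does in this assay, so the size of the step is unknown. Enzymes usually prefer one arrangement, so a weaker inhibitor is expected for the mirror image, though a step no larger than the scatter is also possible. For compound 3 the expected step from compound 1 is a 1.8-fold higher number from compound 1 to compound 3 (0.26 log units; within the scatter). Compound 3 is therefore estimated at 40000 nM, with a range from 12000 nM to 150000 nM.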

Compound 3, half-maximal inhibitory concentration: 28300 nM
Estimate against measurement, compound 3: 1.4-fold (0.15 log units) above; low and high end bracket the measured number.
By their numbers in this assay, from the lowest: compounds 1, 2 and 3 (each within the scatter of the next).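

Within the data shown here, this pair is the first to show what reversing both stereocentres on the saturated chain does in this assay. The result is a 1.3-fold higher number from compound 1 to compound 3 (0.11 log units; within the scatter), so compound 1 and compound 3 cannot be told apart, and no preference for either mirror image can be read from this assay. One caveat applies to treating the pair as a clean reversal: the fact that one of compounds 1 and 3 is drawn with a defined configuration and the other without, at the place where they differ.

Still open, from the compounds shown here alone, is what reversing only one of the two stereocentres would do, since compound 1 and compound 3 differ at both. Also open, going by these compounds, is whether the same indifference to configuration would hold with an amine in place of the azide, or with a longer chain.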